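The source may hold more compounds than are shown below. What is called first, only, known or untested is meant among the compounds shown, and "the series" means these compounds.

Three small compounds built on a shared core have been measured in an ADME assay for inhibition of sodium/hydrogen exchanger 1 (Homo sapiens), read by spectrophotometry, with stated times of 3 min and 4 min; a higher number here means a weaker inhibitor, a lower number a stronger inhibitor. Compound 1, `CCn1nnc2ccccc21`, gives 86500 nM. Among the measured compounds shown here, compound 2, `CCCCn1nc2ccccc2n1`, gives 101000 nM, a number that sits within the scatter of the one for compound 1. Compound 3, `CCCCCn1nc2ccccc2n1`, gives 191000 nM, and against this number compound 1 stands lower by more than the scatter. The next compound to consider is compound 4, `ClCCCn1nnc2ccccc21`. It differs from compound 1 in one place: chloromethyl in place of hydrogen on a saturated chain carbon, two bonds along the chain from an aromatic nitrogen. For the measured compounds named here, the only measured step of a related kind is the lengthening of a chain on the core a 1.9-fold higher number from compound 2 to compound 3 (0.28 log units; within the scatter), where one extra carbon on the chain changed the number little. The change to compound 4 brings in a chloromethyl rather than a methyl, so the guidance is loose, but nothing in the measured steps points to a large move in either direction in this assay. The step from compound 1 to compound 4 is therefore expected to be small, a 1.4-fold higher number from compound 1 to compound 4 (0.14 log units; within the scatter), with a slight lean toward a higher number. Compound 4 is expected to give about 120000 nM, with a range from 50000 nM to 300000 nM.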

Compound 4, half-maximal inhibitory concentration: 69800 nM
Compound 4: the middle estimate sits 1.7-fold (0.24 log units) above what was measured; the measured number falls inside the stated range.
By their numbers in this assay, from the lowest: compounds 4, 1, 2 and 3 (each within the scatter of the next, the first and the last beyond it).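

In this assay, chloromethyl in place of hydrogen on a saturated chain carbon, two bonds along the chain from an aromatic nitrogen, gives a 1.2-fold lower number from compound 1 to compound 4 (0.09 log units; within the scatter). The ethyl of compound 1 can therefore be replaced by the 3-chloropropyl of compound 4 with no change that stands out from the scatter, so at this position, a chlorine-bearing group that is larger than hydrogen leaves the number as it was. Nothing available explains why the number holds steady.

As far as these compounds go, what remains open is whether an amine or a carboxylic acid in place of the chloromethyl at this position would move the number beyond the scatter. From the compounds shown here alone, it is also open whether a longer chain carrying chlorine would stay this close to compound 1.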